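Bromo on the fused core: extending the cyano-stilbene pair

A few compounds are considered here, and "the series" means these few. Any claim that something is new, unique, unknown or untested is made for them only; others in the source may bear on it.

Measured so far:
compound 1 `C(=C/c1nc2ncccc2[nH]1)\c1ccccc1` — 7570 nM
compound 2 `N#Cc1ccc(/C=C/c2nc3ncccc3[nH]2)cc1` — 12900 nM

Both numbers come from a functional assay on MCF7 cells (Homo sapiens) for antiproliferative activity, read by MTT assay, with a stated time of 72 h; a higher number here means a weaker inhibitor, a lower number a stronger inhibitor. Within the data shown here, compound 2 sits at one end of the two values; its only neighbour is compound 1, and the step of a 1.7-fold higher number from compound 1 to compound 2 (0.23 log units; within the scatter) lies within the scatter, so the two compounds are not separated by the data. That step was made by cyano in place of hydrogen on an aromatic carbon of the phenyl ring.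

Compound 3 `N#Cc1ccc(/C=C/c2nc3ncc(Br)cc3[nH]2)cc1` is the next analogue: bromo in place of hydrogen on an aromatic carbon. Among the measured compounds shown here, no measured pair changes anything on the fused core, so the one step in hand, a 1.7-fold higher number from compound 1 to compound 2 (0.23 log units; within the scatter), bears on compound 3 only indirectly, as a sign that a single small substituent elsewhere left this assay unchanged beyond the scatter. Nothing in the data sets a direction for the bromo step. The expectation for compound 3 is therefore a step of about a 1.3-fold lower number from compound 2 to compound 3 (0.11 log units; within the scatter), not beyond the scatter, giving an estimated 10000 nM with a range from 3000 nM to 35000 nM.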

Compound 3, half-maximal inhibitory concentration: 7820 nM
Compound 3: the middle estimate sits 1.3-fold (0.11 log units) above what was measured; measured number inside the range.
By their numbers in this assay, from the lowest: compounds 1, 3 and 2 (each within the scatter of the next).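

In this assay, bromo in place of hydrogen on an aromatic carbon of the six-membered aromatic ring with 1 nitrogen, two atoms from the ring nitrogen, gives a 1.6-fold lower number from compound 2 to compound 3 (0.22 log units; within the scatter). Among these compounds, this is the first measured change on the fused system of two rings, and it shows that this carbon accepts bromo, a single heavy atom, without compound 3 separating from compound 2 in this read-out. Together with the earlier step on the phenyl ring, a 1.7-fold higher number from compound 1 to compound 2 (0.23 log units; within the scatter), it means that both single-substituent changes shown so far stay within the scatter, so neither position has yet shown a direction for activity.

No measurement in hand bears on the reason for this result.

A single halogen on this carbon cannot show whether the position is insensitive in general, so an amine, a carboxylic acid or a longer chain such as propyl at the same carbon remains an open test. Also open, from the compounds shown here alone, is whether bromo gives a similar step on the core of compound 1, where the phenyl ring carries no cyano group.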